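The source may report more compounds than this note shows. Statements on the series, on what has been measured and on what is new or still open speak of the compounds shown alone.

Series on one shared core, varied in the ester group on a carbonyl carbon: compound 1 `CC12CCC(C(=O)OCCc3c(-c4ccccc4Cl)c4cc(Cl)ccc4[nH]c3=O)(OC1=O)C2(C)C`, compound 2 `O=C(OCCc1c(-c2ccccc2Cl)c2cc(Cl)ccc2[nH]c1=O)c1ccccc1`, compound 3 `O=C(OCCc1c(-c2ccccc2Cl)c2cc(Cl)ccc2[nH]c1=O)c1cccs1` and the unmeasured compound 4 `C/C=C/C=C/C(=O)OCCc1c(-c2ccccc2Cl)c2cc(Cl)ccc2[nH]c1=O`. In an ADME assay on HepG2 2.2.15 cells (Homo sapiens) for cytotoxicity (a higher number here means that more compound is tolerated, a lower number that less compound is tolerated), compound 2 gives 43000 nM. Compound 3 reaches only a limit of this assay, > 1700000 nM. Compound 1 likewise ends at a limit, > 1800000 nM. Hence an at least 39-fold higher number from compound 2 to compound 3 (1.59 log units; beyond the scatter), while a step that the two limits leave unreadable from compound 1 to compound 3; an at least 41-fold lower number from compound 1 to compound 2 (1.62 log units; beyond the scatter) is the only fully readable step. Compound 4 carries penta-1,3-dien-1-yl in place of thiophen-2-yl on a carbonyl carbon. Within the data shown here, no measured step exchanges an aromatic ring for an open chain, so the direction is uncertain and a limit remains possible. The step is expected to be an at least 4.2-fold lower number from compound 3 to compound 4 (0.62 log units; beyond the scatter). Compound 4 is estimated at 400000 nM, within 40000 nM to 1800000 nM.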

Compound 4, half-maximal cytotoxic concentration: 440000 nM
The estimate for compound 4 lay 1.1-fold (0.04 log units) below the measured number, and the stated range covers the measured number.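

Penta-1,3-dien-1-yl on the carbonyl carbon is the first open chain at this position, and in this assay it gives a measured number rather than a limit. Compound 2 stays lowest, with a 10-fold higher number from compound 2 to compound 4 (1.01 log units; beyond the scatter), so the phenyl ester is set apart from an open-chain ester as well as from the thiophen-2-yl ester. Compound 4 also falls clearly under both limit compounds, with an at least 3.8-fold lower number from compound 3 to compound 4 (0.58 log units; beyond the scatter) and an at least 4.0-fold lower number from compound 1 to compound 4 (0.61 log units; beyond the scatter).

These two steps give only bounds, and the step between compound 1 and compound 3 cannot be read. As far as these compounds go, whether a saturated hexyl chain or an ester group carrying an amine would fall nearer compound 2 or compound 4 remains open.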